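Chain lengthening on the gem-dimethyl lactone acid: compound 4

The source may hold more compounds than are shown below. What is called first, only, known or untested is meant among the compounds shown, and "the series" means these compounds.

The series is a small set of lactone acids carrying a long saturated chain and tested in an assay for inhibition of fatty acid synthase (Rattus norvegicus), tested at 60 uM; a higher number here means more inhibition at the concentration tested (going by the name of the read-out), a lower number less inhibition. Compound 1 `CCCCCCCC[C@H]1OC(=O)C(=C(C)C)[C@@H]1C(=O)O` gives 17.4%, and compound 2 `CCCCCCCCC[C@H]1OC(=O)C(=C(C)C)[C@@H]1C(=O)O` gives 38.4%. Compound 3 `CCCCCCCC[C@H]1OC(=O)C(C)(C)[C@@H]1C(=O)O` gives 16.7%; compound 3 and compound 1 lie within the scatter of each other, while the number for compound 2 stands beyond the scatter above that of compound 3.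

Compound 4 `CCCCCCCCC[C@H]1OC(=O)C(C)(C)[C@@H]1C(=O)O` differs from compound 3 by the change (methyl in place of hydrogen on a saturated chain carbon, eight bonds along the chain from a saturated ring carbon). Among the compounds with values here, the one measured step of the same kind is a number 21 percentage points higher from compound 1 to compound 2 (beyond the scatter), made on the core that carries the isopropylidene group rather than the gem-dimethyl group. Whether the saturated core answers this change the same way is not known from the present numbers; the pair compound 1 and compound 3 only shows that the two cores sit within the scatter of each other at the shorter chain length.

The expectation for compound 4 is therefore a rise of the same order, a number 19.3 percentage points higher from compound 3 to compound 4 (beyond the scatter), with compound 4 estimated at 36%, between 22% and 50%.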

Compound 4, a percentage reported as inhibition, at one concentration (the size of the read-out at that concentration, not a potency): 23.8%
The estimate for compound 4 lay 12.2 percentage points above the measured number, within the range that was stated.
By their numbers in this assay, from the lowest: compounds 3, 1 and 4 (each within the scatter of the next); then compound 2.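

On the core of compound 3, methyl in place of hydrogen at this chain position gives a number 7.1 percentage points higher from compound 3 to compound 4 (within the scatter) in this assay, so on this core the change cannot be told from repeat scatter. The clear rise seen with the same change on the core of compound 1 is therefore not shown to carry over to the core of compound 3. Nor do the numbers establish that the two cores answer differently, as the gap between the two steps does not exceed what two such steps can scatter by: the same change on two cores in this assay, a number 21 percentage points higher (beyond the scatter) from compound 1 to compound 2 and a number 7.1 percentage points higher (within the scatter) from compound 3 to compound 4, 13.9 percentage points apart, within the scatter of two such steps

The compounds shown leave open how either core answers a longer chain. They also leave open whether an amide in place of the carboxylic acid would hold the numbers in this assay.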